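This account rests on a few compounds, and the source may have more. Where it says the series, first, only, none or still open, it means among the compounds named here.

Two compounds share a core and differ only in the group attached to a saturated chain carbon. Compound 1 `CC(C)(Oc1ccccc1)C1OCC(C/C=C\CCC(=O)O)C(c2cccnc2)O1` carries a phenoxy group there, and in an assay for inhibition of prostacyclin synthase (Homo sapiens), using microsomes (on this read-out lower numbers stand for stronger inhibition and higher numbers for weaker inhibition), compound 1 gives 75000 nM. Compound 2 `Cc1ccc(OC(C)(C)C2OCC(C/C=C\CCC(=O)O)C(c3cccnc3)O2)cc1` carries a 4-methylphenoxy group instead, and in this assay compound 2 gives 25000 nM. Among the compounds with values here, the single step between them, a 3.0-fold lower number from compound 1 to compound 2 (0.48 log units; beyond the scatter), is the only measured step so far, and it places compound 2 as the lowest of the two numbers, with compound 1 the nearest.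

Compound 3 `CC(C)(Cc1ccccc1)C1OCC(C/C=C\CCC(=O)O)C(c2cccnc2)O1` is not yet measured. It differs from compound 2 by benzyl in place of 4-methylphenoxy on a saturated chain carbon bound to two saturated chain carbons and a saturated ring carbon. Within the data shown here, this change removes the methyl whose arrival gave the measured step, and it also removes the oxygen, so the only step that bears on it does so indirectly and points toward a higher number. The expected step in this assay is therefore a 2.4-fold higher number from compound 2 to compound 3 (0.38 log units; beyond the scatter), upward. Compound 3 is expected to give about 60000 nM, with a range from 15000 nM to 250000 nM.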

Compound 3, half-maximal inhibitory concentration: 13000 nM
The estimate for compound 3 lay 4.6-fold (0.66 log units) above the measured number; the whole stated range lies above it.
By their numbers in this assay, from the lowest: compounds 3 and 2 (each within the scatter of the next); then compound 1.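

In this assay, benzyl in place of phenoxy on this saturated chain carbon gives a 5.8-fold lower number from compound 1 to compound 3 (0.76 log units; beyond the scatter) and so is the larger of the changes seen so far at this position. The oxygen of phenoxy is therefore not required for inhibition in this small set, since benzyl holds no oxygen and compound 3 still ranks with the lowest numbers. Against 4-methylphenoxy the picture differs, as benzyl gives a 1.9-fold lower number from compound 2 to compound 3 (0.28 log units; within the scatter) and the two groups cannot be told apart here, even though one carries an oxygen and a methyl and the other carries neither; no measurement offered here accounts for any of these steps.

The compounds shown leave open whether 4-methylbenzyl would lower the number from compound 3 in the way that methyl did on phenoxy, which gave a 3.0-fold lower number from compound 1 to compound 2 (0.48 log units; beyond the scatter) in the only such comparison. They also leave open what a longer chain leading to the aromatic ring, or an amine in place of the benzyl carbon, would do at this position.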